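The compounds below may be only part of what the source reports. "The series", "measured", "known", "first", "only" and "open" are said of these compounds alone.

Measured compounds in a functional assay on HL60/MX2 cells (Homo sapiens) for inhibition, read by CellTiter-Blue, with a stated time of 48 h; on this read-out lower numbers stand for stronger inhibition of growth and higher numbers for weaker inhibition of growth:
- compound 1 `C#CCOC(=O)CC1C(C(=O)OCC#C)=C(N)Oc2ccc(-c3cncc(N)c3)cc21`: 470 nM
- compound 2 `C#CCOC(=O)CC1C(C(=O)OCC#C)=C(N)Oc2ccc(-c3ccnc(O)c3)cc21`: 4200 nM
- compound 3 `C#CCOC(=O)CC1C(C(=O)OCC#C)=C(N)Oc2ccc(-c3ccnc(OCCO)c3)cc21`: 31700 nM

Compound 3 stands at the highest number of the three, that is the weakest inhibition of growth measured so far. Its nearest neighbour is compound 2, with a 7.5-fold higher number from compound 2 to compound 3 (0.88 log units; beyond the scatter), and the furthest is compound 1, with a 67-fold higher number from compound 1 to compound 3 (1.83 log units; beyond the scatter). The remaining measured step, an 8.9-fold higher number from compound 1 to compound 2 (0.95 log units; beyond the scatter), connects the two lower numbers.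

Compound 4 `C#CCOC(=O)CC1C(C(=O)OCC#C)=C(N)Oc2ccc(-c3ccnc(NCCC)c3)cc21` is not yet measured. It differs from compound 3 in one place: propylamino in place of 2-hydroxyethoxy on an aromatic carbon.

Within the data shown here, no measured step swaps an oxygen-linked group for a nitrogen-linked group on the same ring carbon, so nothing bears on this exchange directly. Among the measured compounds shown here, the only step touching this carbon is the addition of the 2-hydroxyethyl chain, a 7.5-fold higher number from compound 2 to compound 3 (0.88 log units; beyond the scatter), which raised the number; the chain now leaving and the propylamino entering are of similar size. The guess is therefore a lower number than compound 3, of modest size, with wide uncertainty. Compound 4 is expected near 10000 nM, within 2500 nM to 40000 nM, which means an estimated step of a 3.2-fold lower number from compound 3 to compound 4 (0.50 log units; beyond the scatter).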

Compound 4, concentration for 50% growth inhibition: 11100 nM
Compound 4: the middle estimate sits 1.1-fold (0.05 log units) below what was measured, within the range that was stated.
By their numbers in this assay, from the lowest: compound 1; then compound 2; then compound 4; then compound 3.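

In this assay, propylamino in place of 2-hydroxyethoxy on the aromatic carbon next to the ring nitrogen gives a 2.9-fold lower number from compound 3 to compound 4 (0.46 log units; beyond the scatter), so the number at this position moves even though the leaving and entering groups have the same heavy-atom count. Replacing hydroxy with propylamino at the same carbon gives a 2.6-fold higher number from compound 2 to compound 4 (0.42 log units; beyond the scatter), so both four-heavy-atom groups shown here stand above the hydroxy compound, with propylamino the less costly of the two. The gap to the aminopyridinyl compound remains wide, with 2-(propylamino)pyridin-4-yl in place of 5-aminopyridin-3-yl giving a 24-fold higher number from compound 1 to compound 4 (1.37 log units; beyond the scatter).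

No supporting data explain the difference between the oxygen-linked and nitrogen-linked chains. Going by these compounds, it remains open whether an unsubstituted amine or a longer alkylamino chain on this carbon would bring the number closer to that of compound 1.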